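The compounds below may be only part of what the source reports. "The series", "measured", "known", "first", "only" and "open" are said of these compounds alone.

Working notes on the series. The shared core, carrying a carboxylic acid, is varied at one aromatic carbon of the phenol-bearing ring. Compound 1 `CN(C)C(=O)c1cccc(CNc2ccc3[nH]nc(C(=O)O)c3c2)c1O` carries dimethylcarbamoyl there, compound 2 `CC(C)c1noc(-c2cccc(CNc3ccc4[nH]nc(C(=O)O)c4c3)c2O)n1` carries 3-isopropyl-1,2,4-oxadiazol-5-yl, and compound 3 `Cc1cccc(CNc2ccc3[nH]nc(C(=O)O)c3c2)c1O` carries methyl.

In an assay on isolated protein for inhibition of 2-Hydroxyacid oxidase 1 (Homo sapiens), with stated times of 30 min and 15 min (a higher number here means a weaker inhibitor, a lower number a stronger inhibitor), compound 1 gives only a limit, > 30000 nM, and no number. In this assay compound 2 gives 47 nM. In this assay compound 3 gives 17000 nM, the highest of the two numbers available; its nearest neighbour is compound 2, with a 360-fold higher number from compound 2 to compound 3 (2.56 log units; beyond the scatter).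

Compound 4 `Cc1nc(-c2cccc(CNc3ccc4[nH]nc(C(=O)O)c4c3)c2O)sc1C` is not yet measured. Relative to compound 3 the change is 4,5-dimethyl-1,3-thiazol-2-yl in place of methyl on an aromatic carbon. The step that bears on it most directly is the one in the other direction, a 360-fold higher number from compound 2 to compound 3 (2.56 log units; beyond the scatter), where a five-membered aromatic group with two hetero atoms at the same carbon gave the much lower number; the step of an at least 630-fold lower number from compound 1 to compound 2 (2.80 log units; beyond the scatter) points the same way for that group. A large drop in the number is therefore expected for compound 4, in the direction of compound 2, with the two extra methyl groups on the entering ring adding some uncertainty.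

The estimate for compound 4 in this assay is 120 nM, with a range from 25 nM to 600 nM, corresponding to an expected 140-fold lower number from compound 3 to compound 4 (2.15 log units; beyond the scatter).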

Compound 4, half-maximal inhibitory concentration: 25 nM
For compound 4 the middle estimate is 4.8-fold (0.68 log units) above the measured one; low and high end bracket the measured number.
By their numbers in this assay, from the lowest: compounds 4 and 2 (each within the scatter of the next); then compound 3. At a limit, above all of these: compound 1.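

In this assay, the low number of compound 2 proves not to be confined to the 3-isopropyl-1,2,4-oxadiazol-5-yl group: 4,5-dimethyl-1,3-thiazol-2-yl on the same aromatic carbon, ortho to the hydroxy group, gives a 680-fold lower number from compound 3 to compound 4 (2.83 log units; beyond the scatter). The comparison between the two five-membered aromatic rings gives a 1.9-fold lower number from compound 2 to compound 4 (0.27 log units; within the scatter), so exchanging the oxadiazole for a thiazole and isopropyl for two methyl groups leaves the result unresolved from that of compound 2. The step of an at least 1200-fold lower number from compound 1 to compound 4 (3.07 log units; beyond the scatter) rests on a limit and is therefore only a floor: the limit of > 30000 nM in this assay, at which 1 of the 4 values shown sits.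

The compounds shown do not separate the contribution of the five-membered ring from that of its alkyl groups, a question that an unsubstituted thiazole or a thiazole carrying a longer chain would address. Going by these compounds, it also remains open whether this position needs a five-membered ring at all, as opposed to a six-membered aromatic ring such as phenyl or pyridine, and whether the low numbers persist with a methoxy group in place of the hydroxy group.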